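Working notes: a benzyl exchange from compound 1

This account rests on a few compounds, and the source may have more. Where it says the series, first, only, none or still open, it means among the compounds named here.

In a functional assay on PC-3 cells (Homo sapiens) for cytotoxicity, read by MTT assay, with a stated time of 24 h (a higher number here means a weaker inhibitor, a lower number a stronger inhibitor), compound 1 (`COc1ccc(/C=C2\CN(C(=S)SCc3cn(Cc4ccc(F)cc4)nn3)C/C(=C\c3ccc(OC)cc3)C2=O)cc1`) gives 45600 nM and compound 2 (`O=C1/C(=C/c2ccccc2F)CN(C(=S)SCc2cn(Cc3cccc(Cl)c3)nn2)C/C1=C\c1ccccc1F`) gives 80000 nM. These two numbers lie within the scatter of each other, so neither compound stands apart from the other.

Compound 3 (`COc1ccc(/C=C2\CN(C(=S)SCc3cn(Cc4ccccc4Cl)nn3)C/C(=C\c3ccc(OC)cc3)C2=O)cc1`) keeps the core of compound 1 and carries 2-chlorophenyl in place of 4-fluorophenyl on a saturated chain carbon bound to an aromatic nitrogen. Read one bond further out, this is 4-fluorobenzyl to 2-chlorobenzyl.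

Among the measured compounds shown here, no measured pair differs in only one place, so the data offer no direct guide to this exchange. Only the closeness of the two measured numbers informs the expectation, and no change beyond the scatter is expected in this assay. The expected step is a 1.1-fold higher number from compound 1 to compound 3 (0.04 log units; within the scatter). For compound 3, the estimated value is 50000 nM, with an expected range of 22000 nM to 100000 nM.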

Compound 3, half-maximal inhibitory concentration: 60100 nM
Compound 3: middle estimate off by 1.2-fold (0.08 log units), on the low side; measured number inside the range.
By their numbers in this assay, from the lowest: compounds 1, 3 and 2 (each within the scatter of the next).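

In this assay, among the compounds shown here, the exchange of 4-fluorobenzyl for 2-chlorobenzyl gives a 1.3-fold higher number from compound 1 to compound 3 (0.12 log units; within the scatter), the first step that can be read at a single place. On a saturated chain carbon bound to an aromatic nitrogen, 2-chlorophenyl and 4-fluorophenyl therefore cannot be told apart in this read-out, something the earlier pair could not show because its members differ in more than one place. No measurement bearing on this result accompanies the two groups.

Still open, on these data alone, is whether anything other than a halogen-bearing benzyl moves the number at this position, for instance a benzyl carrying a carboxylic acid or an amine, or a longer chain between the phenyl ring and the aromatic nitrogen. Also open, as far as these compounds go, is whether the same exchange reads alike on the core of compound 2.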